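Fluorine position on the saturated-ring aryl of compound 4

The source may report more compounds than this note shows. Statements on the series, on what has been measured and on what is new or still open speak of the compounds shown alone.

Working notes on the series. Compound 1 `NS(=O)(=O)c1ccc(N2N=C(c3ccc(Oc4ccccc4)cc3)CC2c2ccccc2F)cc1` is the reference point; in an ADME assay on Vero 76 cells (Chlorocebus sabaeus) for cytotoxicity, read by MTT assay, with a stated time of 96 h (on this read-out higher numbers stand for lower toxicity in this test and lower numbers for higher toxicity in this test), compound 1 gives 96000 nM. Compound 2 `NS(=O)(=O)c1ccc(N2N=C(c3ccccc3)CC2c2ccccc2F)cc1` gives 28000 nM, and compound 3 `Cc1ccc(C2CC(c3ccc(OCc4ccccc4)cc3)=NN2c2ccc(S(N)(=O)=O)cc2)cc1` gives 100000 nM. For the measured compounds named here, compound 1 and compound 3 lie within the scatter of each other, while the step of a 3.4-fold lower number from compound 1 to compound 2 (0.54 log units; beyond the scatter) is the only measured step that separates two compounds beyond the scatter, and the values of compound 3 and compound 2 show the same ordering.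

Compound 4 `NS(=O)(=O)c1ccc(N2N=C(c3ccc(Oc4ccccc4)cc3)CC2c2cccc(F)c2)cc1` is not yet measured. Relative to compound 1 it differs by 3-fluorophenyl in place of 2-fluorophenyl on a saturated ring carbon. Going by the values given here, no measured pair changes only the position of the fluorine on this ring; the one measured step, a 3.4-fold lower number from compound 1 to compound 2 (0.54 log units; beyond the scatter), concerns hydrogen in place of phenoxy on an aromatic carbon and does not bear directly on this change. With no relevant comparison available, compound 4 is expected to give about the same number as compound 1, with no change at the digits printed from compound 1 to compound 4 (within the scatter) estimated to remain within the scatter. The estimate for compound 4 is 96000 nM, expected between 40000 nM and 200000 nM.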

Compound 4, half-maximal cytotoxic concentration: 28000 nM
The estimate for compound 4 lay 3.4-fold (0.54 log units) above the measured number; measured number below the stated range.
By their numbers in this assay, from the lowest: compounds 2 and 4 (each within the scatter of the next); then compounds 1 and 3 (each within the scatter of the next).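

The position on the saturated ring carbon is not silent in this assay: moving the fluorine alone, with the same atoms and the same counts in the group, gives a 3.4-fold lower number from compound 1 to compound 4 (0.54 log units; beyond the scatter) and so reads as higher toxicity in this test. For the compounds shown here, the earlier compounds showed a step of this kind only for the removal of phenoxy, so this is the first sign that the placement of a single fluorine on this aryl ring matters. Nothing available explains why the number follows the fluorine position.

From the compounds shown here alone, whether the same fluorine move has an effect when hydrogen replaces phenoxy remains open. Going by these compounds, it is also open whether a chlorine or an amine in place of the fluorine on this ring would shift the number in the same direction.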